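The source may report more compounds than this note shows. Statements on the series, on what has been measured and on what is new or still open speak of the compounds shown alone.

Working notes on the series.

Compound 3 `CCCSc1nc(N/N=C/c2ccc([N+](=O)[O-])cc2)c2nnn(Cc3ccccc3)c2n1` gives 6640 nM in a functional assay on ECa-109 cells (Homo sapiens) for antiproliferative activity, read by MTT assay, with a stated time of 72 h (on this read-out lower numbers stand for stronger inhibition and higher numbers for weaker inhibition), the lowest of the two numbers in hand. Compound 2 `CCCSc1nc(N/N=C/c2ccc(N(C)C)cc2)c2nnn(Cc3ccccc3)c2n1` gives 20000 nM in this assay. Compound 1 `CCCSc1nc(N/N=C/c2ccccc2F)c2nnn(Cc3ccccc3)c2n1` reaches only a limit, > 64000 nM, in this assay. The steps of a 3.0-fold lower number from compound 2 to compound 3 (0.48 log units; beyond the scatter) and an at least 9.6-fold lower number from compound 1 to compound 3 (0.98 log units; beyond the scatter) both show that the 4-nitrophenyl group brought the number down.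

Compound 4 `CCCSc1nc(N/N=C/c2ccccc2)c2nnn(Cc3ccccc3)c2n1` is not yet measured. It differs from compound 3 by hydrogen in place of nitro on an aromatic carbon. The bearing steps are those into compound 3: taking the nitro away should reverse part of a 3.0-fold lower number from compound 2 to compound 3 (0.48 log units; beyond the scatter), so a higher number in this assay is expected, probably of modest size. The expected step is a 3.0-fold higher number from compound 3 to compound 4 (0.48 log units; beyond the scatter), giving compound 4 an estimated 20000 nM, in the range 8000 nM to 50000 nM.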

Compound 4, half-maximal inhibitory concentration: > 64000 nM
Compound 4 was reported as a limit; the forecaster's own chance of this, stated with the estimate: 15%; middle value at least 3.2-fold (0.50 log units) from the limit.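

Hydrogen at this position, para to a large group, is the bare reference the earlier compounds lacked, and against it both substituents count: an at least 9.6-fold higher number from compound 3 to compound 4 (0.98 log units; beyond the scatter) and an at least 3.2-fold higher number from compound 2 to compound 4 (0.50 log units; beyond the scatter). Nitro and dimethylamino thus each give a readable number on this ring, while the phenyl of compound 4 does not. Compound 1 and compound 4 cannot be ordered, and their step cannot be read, because both stand at the same limit: the limit of > 64000 nM in this assay, at which 2 of the 4 values shown sit.

On these data alone, whether a carboxylic acid or a primary amine at this position would go lower than compound 3 remains open. Also open, as far as these compounds go, is whether a nitro group elsewhere on the ring would keep the gain.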